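Same atoms, joined differently, in a side chain

The compounds below may be only part of what the source reports. "The series", "measured", "known", "first", "only" and "open" are said of these compounds alone.

In a physicochemical assay for solubility, read by HPLC, at pH 7.4 (on this read-out higher numbers stand for higher solubility and lower numbers for lower solubility), compound 1 (`CCCCCOCc1cc(=O)c2ccccc2[nH]1`) gives > 200000 nM, which is a limit of the assay and not a number. Compound 1 therefore stands at the limit of > 200000 nM in this assay, at which 1 of the 2 values shown sits. Compound 2 (`CCCCCOCc1cc(=O)c2cc([N+](=O)[O-])ccc2[nH]1`) gives 15000 nM. Going by the values given here, the only measured step is an at least 13-fold lower number from compound 1 to compound 2 (1.12 log units; beyond the scatter), and it puts nitro in place of hydrogen on an aromatic carbon. Compound 3 (`CCOCCCCc1cc(=O)c2ccccc2[nH]1`) has the same atoms as compound 1, joined differently: 3-ethoxypropyl in place of pentyloxy on a saturated chain carbon bound to an aromatic carbon. Here 3-ethoxypropyl stands in place of pentyloxy on a saturated chain carbon bound to an aromatic carbon. That is a different change from the measured one, and compound 3 carries no nitro, so the fall seen in compound 2 to 15000 nM is not expected to recur. No step beyond the scatter is therefore expected in this assay. The estimated step is a number no higher from compound 1 to compound 3 (the limit leaves the size open). For compound 3 the expected value is 200000 nM, with an estimated range from 70000 nM to 400000 nM.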

Compound 3, solubility: > 200000 nM
Compound 3: a limit, no number; the forecaster's own chance of this, stated with the estimate: 60%; the middle value lies on the limit itself.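

In this assay compound 1 and compound 3 each give a limit and not a number, so no step between them can be read: the limit of > 200000 nM in this assay, at which 2 of the 3 values shown sit.

The compounds shown leave open whether pentyloxy and 3-ethoxypropyl differ at all in solubility.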